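Swapping the imidazole for chloro on the propoxy chain

A few compounds are considered here, and "the series" means these few. Any claim that something is new, unique, unknown or untested is made for them only; others in the source may bear on it.

Of the compounds shown here, three sharing one core have been measured in an assay on CHO cells for displacement of a labelled ligand from adenosine receptor A3 (Homo sapiens), read by scintillation counting, with a stated time of 3 h; on this read-out higher numbers stand for weaker inhibition and lower numbers for stronger inhibition. Compound 1 `Cn1c(=O)c2[nH]c(-c3ccc(OCCC4CCNCC4)cc3)nc2n(C)c1=O` gives 6.51 nM, compound 2 `Cn1c(=O)c2[nH]c(-c3ccc(OCCCn4ccnc4)cc3)nc2n(C)c1=O` gives 2.27 nM, and compound 3 `Cn1c(=O)c2[nH]c(-c3ccc(OCCCN4CCN(Cc5ccccc5Cl)CC4)cc3)nc2n(C)c1=O` gives 6.89 nM. Compound 2 thus holds the lowest number of the three, with compound 1 and compound 3 both higher beyond the scatter. Among the measured compounds shown here, the only single-point step among them is a 2.9-fold lower number from compound 1 to compound 2 (0.46 log units; beyond the scatter), showing that the group at the end of the chain moves the number modestly. Compound 4 `Cn1c(=O)c2[nH]c(-c3ccc(OCCCCl)cc3)nc2n(C)c1=O` is not yet measured; it differs from compound 2 by chloro in place of 1H-imidazol-1-yl on a saturated chain carbon, three bonds along the chain from an oxygen on an aromatic ring. For the measured compounds named here, no measured step removes a ring from this chain end, so the expectation leans on the modest range seen across compounds 1, 2 and 3. Since compound 2 sits at the low end of that range, compound 4 is expected to give a somewhat higher number, a 2.6-fold higher number from compound 2 to compound 4 (0.42 log units; beyond the scatter), yielding an estimate of 6 nM within 1.8 nM to 20 nM.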

Compound 4, inhibition constant: > 30 nM
Compound 4: a limit, no number; the forecaster's own chance of this, stated with the estimate: 2%; at least 5.0-fold (0.69 log units) between middle value and limit.
By their numbers in this assay, from the lowest: compound 2; then compounds 1 and 3 (each within the scatter of the next). At a limit, above all of these: compound 4.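

In this assay compound 4 gives > 30 nM, which is a limit of the assay and not a number. Against that limit the readings are an at least 13-fold higher number from compound 2 to compound 4 (1.12 log units; beyond the scatter) and an at least 4.6-fold higher number from compound 1 to compound 4 (0.66 log units; beyond the scatter), the first of these a large step, whereas the only step among the earlier compounds was modest. So the position on a saturated chain carbon, three bonds along the chain from an oxygen on an aromatic ring, proves far more sensitive than the earlier compounds showed: replacing 1H-imidazol-1-yl with chloro, which leaves no ring at the chain end, costs much of the binding.

From the compounds shown here alone, the true number of compound 4 stays open, so the full size of these steps is unknown. Also open, going by these compounds, is whether a plain amine or a hydroxyl group at the same chain end would keep the number low without any ring.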